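The compounds below may be only part of what the source reports. "The series", "measured", "known", "first", "only" and "open" are said of these compounds alone.

Measured compounds in a functional assay for inhibition, with Homo sapiens as the target; a lower number here means that less compound is needed, a higher number that more compound is needed for the effect:
compound 1, `CC(=O)Nc1ccc(C2=NNC(=O)CC2)cc1`, gives 1 ug/mL
compound 2, `CC(=O)Nc1ccc(C2=NNC(=O)C(C)C2)cc1`, gives 46.4 ug/mL
compound 3, `O=C1CCC(c2ccc(NC(=O)CCl)cc2)=NN1`, gives 0.39 ug/mL

Compound 2 differs from compound 1 by methyl in place of hydrogen on a saturated ring carbon, and this change brought a 46-fold higher number from compound 1 to compound 2 (1.67 log units; beyond the scatter). Compound 3 differs from compound 1 by chloro in place of hydrogen on a saturated chain carbon bound to a carbonyl carbon, which brought a 2.6-fold lower number from compound 1 to compound 3 (0.41 log units; beyond the scatter). Of the three measured numbers, compound 3 has the lowest.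

Compound 4, `CC1CC(c2ccc(NC(=O)CCl)cc2)=NNC1=O`, has not yet been measured. It differs from compound 3 by methyl in place of hydrogen on a saturated ring carbon. For the measured compounds named here, this is the same change as the one from compound 1 to compound 2, made at a place described in identical words, but on the core of compound 3 rather than the core of compound 1; the two cores differ as told by chloro in place of hydrogen on a saturated chain carbon bound to a carbonyl carbon.

For compound 4 the step of a 46-fold higher number from compound 3 to compound 4 (1.66 log units; beyond the scatter) is expected in this assay, resting on the step of a 46-fold higher number from compound 1 to compound 2 (1.67 log units; beyond the scatter) seen once before for this change. Going by the values given here, since only one example of the change exists, the expectation is uncertain. Compound 4 is estimated at 18 ug/mL, within 5 ug/mL to 60 ug/mL.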

Compound 4, half-maximal effective concentration: 21.9 ug/mL
Compound 4: the middle estimate sits 1.2-fold (0.09 log units) below what was measured; low and high end bracket the measured number.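

In this assay, methyl in place of hydrogen on a saturated ring carbon gave a 56-fold higher number from compound 3 to compound 4 (1.75 log units; beyond the scatter), and this large step matches the earlier one on the core of compound 1: the same change on two cores in this assay, a 46-fold higher number (1.67 log units; beyond the scatter) from compound 1 to compound 2 and a 56-fold higher number (1.75 log units; beyond the scatter) from compound 3 to compound 4, 1.2-fold (0.08 log units) apart, within the scatter of two such steps. The chloro change carried over in the same way, giving a 2.1-fold lower number from compound 2 to compound 4 (0.33 log units; beyond the scatter) on the core that already bears the methyl: the same change on two cores in this assay, a 2.6-fold lower number (0.41 log units; beyond the scatter) from compound 1 to compound 3 and a 2.1-fold lower number (0.33 log units; beyond the scatter) from compound 2 to compound 4, 1.2-fold (0.08 log units) apart, within the scatter of two such steps. Within these four compounds, each change therefore shifted the number by about the same amount whether or not the other was present, but this rests on only two cores and a single pair of changes, so it does not show that either step would hold on other cores in the series, nor why the methyl has so large an effect.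

The compounds shown leave open what ethyl in place of the methyl, or bromo or an amine in place of the chloro, would do to the number. As far as these compounds go, it also remains open whether such groups would combine as predictably as these two did.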